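The source may hold more compounds than are shown below. What is called first, only, known or untested is meant among the compounds shown, and "the series" means these compounds.

Measured so far:
compound 1, `O=C(CSc1nnc(-c2ccncc2)o1)N/N=C/c1ccccc1F`: in a functional assay on SW 1116 cells (Homo sapiens) for cytotoxicity, read by MTT assay, with a stated time of 48 h (on this read-out lower numbers stand for stronger inhibition and higher numbers for weaker inhibition), compound 1 gives 21500 nM
compound 2, `O=C(CSc1nnc(-c2ccncc2)o1)N/N=C/c1cc(Cl)cc(Cl)c1O`: in this assay compound 2 gives 5030 nM

Going by the values given here, compound 2 holds the lowest of the two numbers; its only neighbour, compound 1, stands one step away, a 4.3-fold lower number from compound 1 to compound 2 (0.63 log units; beyond the scatter). Compound 3, `COc1cc(/C=N/NC(=O)CSc2nnc(-c3ccncc3)o2)ccc1O`, has not yet been measured in this assay. It differs from compound 2 in one place: 4-hydroxy-3-methoxyphenyl in place of 3,5-dichloro-2-hydroxyphenyl on a carbon with a double bond to nitrogen. Among the compounds with values here, the single measured step, a 4.3-fold lower number from compound 1 to compound 2 (0.63 log units; beyond the scatter), shows that exchanging the ring on the carbon with a double bond to nitrogen moves the number modestly, but it concerns a different pair of rings and so gives no direct guide to the direction here. Within the data shown here, compound 3 keeps one hydroxyl on its ring and carries a methoxy group instead of the two chlorines; no measured compound has such a ring. The number for compound 3 is therefore expected to fall between the two measured values, with a step of a 1.8-fold higher number from compound 2 to compound 3 (0.25 log units; within the scatter) expected, modest and toward a higher number. Compound 3 is estimated at 9000 nM, within the range 3000 nM to 30000 nM.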

Compound 3, half-maximal inhibitory concentration: 3590 nM
Estimate against measurement, compound 3: 2.5-fold (0.40 log units) above; low and high end bracket the measured number.
By their numbers in this assay, from the lowest: compounds 3 and 2 (each within the scatter of the next); then compound 1.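

In this assay the ring on the carbon with a double bond to nitrogen can lose both chlorines without a change that can be read: the exchange of 3,5-dichloro-2-hydroxyphenyl for 4-hydroxy-3-methoxyphenyl gives a 1.4-fold lower number from compound 2 to compound 3 (0.15 log units; within the scatter), so compound 2 and compound 3 cannot be told apart here, although their rings differ in atoms and in where their groups sit. Going by these compounds alone, the 2-fluorophenyl ring of compound 1 now stands apart from both, since a 6.0-fold lower number from compound 1 to compound 3 (0.78 log units; beyond the scatter) adds a second step beyond the scatter to the one already seen with compound 2, and the two rings that carry a hydroxy group match each other. Nothing available explains why these rings give these numbers.

On these data alone, what remains open is whether the hydroxy group alone accounts for the gap to compound 1, since both rings that match also carry other groups. Also open, as far as these compounds go, is how the number would respond to a plain phenyl ring, or to a ring bearing an amine or a carboxylic acid at this same place on the shared core.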